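A Bromophenyl for a Methylphenyl on Two Different Cores

A few compounds are considered here, and "the series" means these few. Any claim that something is new, unique, unknown or untested is made for them only; others in the source may bear on it.

Compound 1, `Cc1ccc(Nc2nnc(-c3ccc(C)cc3C)s2)cc1`, and compound 2, `Cc1ccc(-c2nnc(Nc3cccc(Br)c3)s2)c(C)c1`, share one core. In an assay on isolated protein for inhibition of beta-glucuronidase (Bos taurus), read by spectrophotometry, with a stated time of 30 min (on this read-out higher numbers stand for weaker inhibition and lower numbers for stronger inhibition), compound 1 gives 34300 nM, and compound 2 gives 36100 nM; the change 3-bromophenyl in place of 4-methylphenyl on a nitrogen on an aromatic ring made a step of a 1.1-fold higher number from compound 1 to compound 2 (0.02 log units; within the scatter). Compound 3, `COc1ccccc1-c1nnc(Nc2ccc(C)cc2)s1`, carries a different core, and the difference between the two cores is not broken down here. In this assay compound 3 gives 58100 nM, which sits within the scatter of the other two numbers. Compound 4, `COc1ccccc1-c1nnc(Nc2cccc(Br)c2)s1`, has not yet been measured; it carries the same change as before, (3-bromophenyl in place of 4-methylphenyl on a nitrogen on an aromatic ring), at the same kind of place. Because the earlier step of a 1.1-fold higher number from compound 1 to compound 2 (0.02 log units; within the scatter) stayed within the scatter, the same change on the core of compound 3 is expected to give a 1.1-fold higher number from compound 3 to compound 4 (0.03 log units; within the scatter). Compound 4 is therefore estimated to give 62000 nM in this assay, with a likely range from 30000 nM to 130000 nM.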

Compound 4, half-maximal inhibitory concentration: 49200 nM
For compound 4 the middle estimate is 1.3-fold (0.10 log units) above the measured one, within the range that was stated.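

In this assay, putting 3-bromophenyl in place of 4-methylphenyl on the core of compound 3 made a step of a 1.2-fold lower number from compound 3 to compound 4 (0.07 log units; within the scatter). Set beside the earlier step, the change looks the same on both cores: the same change on two cores in this assay, a 1.1-fold higher number (0.02 log units; within the scatter) from compound 1 to compound 2 and a 1.2-fold lower number (0.07 log units; within the scatter) from compound 3 to compound 4, 1.2-fold (0.09 log units) apart, within the scatter of two such steps

So on these two cores the swap leaves the number within the scatter, but this does not show that it would do so on any other core, and neither group can be ranked above the other.

On these data alone, it remains open whether a carboxylic acid or an amine in place of the bromine would shift the number beyond the scatter. As far as these compounds go, the effect of a longer chain in place of the whole aromatic ring also remains open.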